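Trading Two Methoxy Groups for a Methyl on an Ether

The source may report more compounds than this note shows. Statements on the series, on what has been measured and on what is new or still open speak of the compounds shown alone.

Measured so far in a functional assay on HCT-116 cells (Homo sapiens) for inhibition, read by sulforhodamine B assay, with a stated time of 48 h; on this read-out lower numbers stand for stronger inhibition and higher numbers for weaker inhibition:
Compound 1 `COc1cc(COC(c2ccc(OC)c(OC)c2OC)c2cccc3ccccc23)cc(OC)c1` gives > 20000 nM, a limit of the assay rather than a number.
Compound 2 `COc1ccc(/C(=N/O)c2cccc3ccccc23)c(OC)c1OC` gives 5880 nM.
Compound 3 `COc1ccc(C(O)(Cc2ccc(C)cc2)c2cccc3ccccc23)c(OC)c1OC` gives > 20000 nM, again a limit of the assay and not a number.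

Compound 1 therefore stands at the upper edge of what this assay can report: it is one of the two compounds for which only a limit is known, and (the limit of > 20000 nM in this assay, at which 2 of the 3 values shown sit). For the measured compounds named here, only compound 2, the oxime, returns an actual number, and no two of the measured compounds differ in a single place, so no step has yet been measured against which a change could be calibrated.

Compound 4 `COc1ccc(C(OCc2ccc(C)cc2)c2cccc3ccccc23)c(OC)c1OC` keeps the shared core of compound 1 and changes one part: 4-methylphenyl in place of 3,5-dimethoxyphenyl on a saturated chain carbon bound to an oxygen on a saturated carbon. Compound 3, which also carries a 4-methylbenzyl group, gives > 20000 nM, a limit, and this is the only hint available. The step from compound 1 to compound 4 is expected to be small or absent beyond the scatter, a number no higher from compound 1 to compound 4 (the limit leaves the size open), in this assay. Compound 4 is thus estimated at 20000 nM, with a range from 6000 nM to 60000 nM, most likely reported again as a limit.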

Compound 4, half-maximal inhibitory concentration: > 20000 nM
Compound 4 gave a limit, no number; the forecaster's own chance of this, stated with the estimate: 65%; the middle value lies on the limit itself.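

In this assay compound 4 gives > 20000 nM, a limit of the assay and not a number. For the compounds shown here, compound 1 also stands at a limit, so no step between compound 1 and compound 4 can be read. The compounds shown leave open whether 4-methylphenyl in place of 3,5-dimethoxyphenyl changes inhibition at all: the limit of > 20000 nM in this assay, at which 3 of the 4 values shown sit.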